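The source may hold more compounds than are shown below. What is called first, only, known or untested is meant among the compounds shown, and "the series" means these compounds.

The measured compounds:
Compound 1, `CCCCCCCN1CCC(C(=O)Nc2cc(Cl)c(N)cc2OC)CC1`, gives > 10 mg/kg in a functional assay on the whole organism for antagonist activity, with Mus musculus as the target (on this read-out lower numbers stand for an effect already at smaller amounts and higher numbers for an effect only at larger amounts of compound), which is a limit of the assay and not a number.
Compound 2, `COc1cc(N)c(Cl)cc1NC(=O)C1CCN(Cc2ccc(Cl)cc2)CC1`, gives 1.2 mg/kg in this assay.

Among the measured compounds shown here, compound 2 thus stands as the only compound with a number in this assay; the other value shown is a limit (the limit of > 10 mg/kg in this assay, at which 1 of the 2 values shown sits). For the measured compounds named here, the one measured step, an at least 8.3-fold lower number from compound 1 to compound 2 (0.92 log units; beyond the scatter), changed the group on the saturated chain carbon bound to the amine nitrogen in the ring. Compound 3, `CCOc1ccc(CN2CCC(C(=O)Nc3cc(Cl)c(N)cc3OC)CC2)cc1`, differs from compound 2 in another place: ethoxy in place of chloro on an aromatic carbon. Going by the values given here, no measured step touches the aromatic ring where this exchange takes place, so the exchange of hexyl for 4-chlorophenyl gives no direct guidance; it shows only that compound 2, carrying the 4-chlorophenyl, lies well inside the measurable range. Among the compounds with values here, with no comparable step to draw on, the expected step is a 1.3-fold higher number from compound 2 to compound 3 (0.10 log units; within the scatter), within the scatter. Compound 3 is therefore estimated at 1.5 mg/kg in this assay, between 0.5 mg/kg and 5 mg/kg.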

Compound 3, dose for half-maximal effect: 6.3 mg/kg
Compound 3: the middle estimate sits 4.2-fold (0.62 log units) below what was measured; measured number above the stated range.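

Among the compounds shown here, this is the first measured change at the aromatic carbon para to a large group, and in this assay the position proves sensitive: ethoxy in place of chloro gives a 5.3-fold higher number from compound 2 to compound 3 (0.72 log units; beyond the scatter). The 4-chlorophenyl and the 4-ethoxyphenyl are therefore not interchangeable here, and of the pair the chloro compound acts at the smaller dose. The exchange of hexyl for 4-ethoxyphenyl gives an at least 1.5-fold lower number from compound 1 to compound 3 (0.20 log units; that floor lies within the scatter), a floor that does not by itself set those compounds apart, because the value of compound 1 is a limit of the assay and not a number: the limit of > 10 mg/kg in this assay, at which 1 of the 3 values shown sits.

The compounds shown leave open whether the higher number follows from the oxygen of the ethoxy, from its carbon chain or from the loss of the chloro, since these all change together in this one exchange. A methoxy, a methyl, a fluoro or a bromo at the same place could help to separate these readings, and a hydrogen there would show what the chloro itself contributes.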